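Amine swap from compound 3 toward the indole pair

The source may hold more compounds than are shown below. What is called first, only, known or untested is meant among the compounds shown, and "the series" means these compounds.

Going by the values given here, in a functional assay on K562 cells (Homo sapiens) for inhibition, read by trypan blue exclusion, with a stated time of 72 h (a lower number here means a stronger inhibitor, a higher number a weaker inhibitor), compound 3 `Cc1ccc(S(=O)(=O)c2cc3cnc(Nc4cnc5c(c4)CC(=O)N5)nc3n(C)c2=O)cc1` gives 15000 nM, the highest of the three numbers so far. Compound 1 `Cn1c(=O)c(S(=O)(=O)c2ccc(F)cc2F)cc2cnc(Nc3cccc4[nH]ccc34)nc21` gives 1500 nM and compound 2 `Cn1c(=O)c(S(=O)(=O)c2ccc(F)cc2)cc2cnc(Nc3cccc4[nH]ccc34)nc21` gives 750 nM, each beyond the scatter from compound 3. Compound 4 `Cc1ccc(S(=O)(=O)c2cc3cnc(Nc4cccc5[nH]ccc45)nc3n(C)c2=O)cc1` differs from compound 3 in one place: a group of 9 heavy atoms (8 carbon, 1 nitrogen; one five-membered aromatic ring with 1 hetero atom, one six-membered aromatic ring of carbon only) in place of a group of 10 heavy atoms (7 carbon, 2 nitrogen, 1 oxygen; one five-membered non-aromatic ring with 1 hetero atom, one six-membered aromatic ring with 1 hetero atom), on a nitrogen on an aromatic ring. Among the compounds with values here, the only measured step, a 2.0-fold lower number from compound 1 to compound 2 (0.30 log units; within the scatter), concerns the aryl on the sulfonyl and does not bear on this change; no measured pair isolates the amine swap. Compound 1 and compound 2 carry the same 1H-indol-4-yl as compound 4, so a step down toward their numbers is expected, a 15-fold lower number from compound 3 to compound 4 (1.18 log units; beyond the scatter). Compound 4 is estimated at 1000 nM, between 300 nM and 4000 nM.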

Compound 4, half-maximal inhibitory concentration: 5000 nM
The estimate for compound 4 lay 5.0-fold (0.70 log units) below the measured number; the measured number lies above the stated range.
By their numbers in this assay, from the lowest: compounds 2 and 1 (each within the scatter of the next); then compound 4; then compound 3.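

In this assay, 1H-indol-4-yl on the nitrogen on an aromatic ring brings only a modest gain (a 3.0-fold lower number from compound 3 to compound 4 (0.48 log units; beyond the scatter)), so the amine alone does not reach the fluorinated compounds. The aryl on the sulfonyl also counts, which the earlier pair did not show: a 6.7-fold higher number from compound 2 to compound 4 (0.82 log units; beyond the scatter), and a 3.3-fold higher number from compound 1 to compound 4 (0.52 log units; beyond the scatter). No measurement at hand accounts for either effect.

As far as these compounds go, whether the two places add up remains open, as the amine of compound 3 is paired only with 4-methylphenyl. A methoxy or chloro in place of the methyl on that aryl is also untested here.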